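Flipping the Stereocentre in the Bulkier Urea

A few compounds are considered here, and "the series" means these few. Any claim that something is new, unique, unknown or untested is made for them only; others in the source may bear on it.

Measured so far in an ADME assay on the whole organism with Oryza sativa as the target, tested at 10 uM; on this read-out higher numbers stand for a weaker effect at the one concentration tested and lower numbers for a stronger effect:
Compound 1, `C[C@@H](NC(=O)Nc1ccccc1C(C)(C)C)c1ccccc1`, gives 17%.
Compound 2, `C[C@H](NC(=O)Nc1ccccc1C(C)(C)C)c1ccccc1`, gives 100%.
Compound 3, `C[C@@H](NC(=O)Nc1cc(C(C)(C)C)ccc1C(C)(C)C)c1ccccc1`, gives 99%.

Compound 3 sits second highest of the three numbers; the gap to compound 2 is within the scatter, while compound 1 lies far below it.

The step considered here goes from compound 3 to compound 4, `C[C@H](NC(=O)Nc1cc(C(C)(C)C)ccc1C(C)(C)C)c1ccccc1`, which is yet to be measured. The change is the two compounds have the same atoms and bonds and differ only in configuration as drawn: 1 of 1 stereo elements differ; a stereocentre at a saturated chain carbon is drawn R in compound 3 and S in compound 4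

The same kind of change has already been seen once: a number 83 percentage points higher from compound 1 to compound 2 (beyond the scatter), and that step is tied to the fact that compounds 1 and 2 differ only in the configuration as drawn. Taken alone, this would suggest a large rise from compound 3 to compound 4. Compound 3, however, already gives a number at the top of what this read-out can report, so there is little room left for a rise of that size. The expected step is therefore no change at the digits printed from compound 3 to compound 4 (within the scatter), which lies within the scatter. Compound 4 is expected to give about 99%, somewhere between 85% and 100%.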

Compound 4, a percentage reported as activity, at one concentration (the size of the read-out at that concentration, not a potency): 97%
Compound 4: middle estimate off by 2 percentage points, on the high side; low and high end bracket the measured number.
By their numbers in this assay, from the lowest: compound 1; then compounds 4, 3 and 2 (each within the scatter of the next).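

On the core carrying the added tert-butyl, flipping the stereocentre no longer separates the two compounds in this assay: the step is a number 2 percentage points lower from compound 3 to compound 4 (within the scatter), against a number 83 percentage points higher from compound 1 to compound 2 (beyond the scatter) on the core without it. Adding that tert-butyl in place of hydrogen on an aromatic carbon now gives a number 3 percentage points lower from compound 2 to compound 4 (within the scatter), so the same change has a very different outcome depending on the configuration: the same change on two cores in this assay, a number 82 percentage points higher (beyond the scatter) from compound 1 to compound 3 and a number 3 percentage points lower (within the scatter) from compound 2 to compound 4, 85 percentage points apart, beyond the scatter of two such steps. Among these four compounds, configuration therefore makes a measurable difference only on the core without the added tert-butyl, and compound 1 alone stands apart from the others.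

On these data alone, it remains open whether a smaller group such as methyl at that aromatic carbon would keep the difference between the two configurations. Whether an amine or a carboxylic acid there would behave like hydrogen or like tert-butyl is also unknown.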